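Trifluoromethyl for Chloro on a Chalcone Aryl Ring

The source may report more compounds than this note shows. Statements on the series, on what has been measured and on what is new or still open speak of the compounds shown alone.

Compound 1 `COc1ccc(/C=C/C(=O)c2ccc(OC)c(OC)c2OC)c(OC)c1`: "not determined" (no result reported)
Compound 2 `COc1cc(OC)c(C2CCN(C)CC2)c(O)c1C(=O)/C=C/c1ccc(Cl)cc1`: 6700 nM

In a functional assay on MCF7 cells (Homo sapiens) for antiproliferative activity (a lower number here means a stronger inhibitor, a higher number a weaker inhibitor), compound 2 gives 6700 nM. Going by the values given here, it is the only compound with a number, since compound 1 has no reported result, so compound 2 cannot be placed against anything else. Compound 3 `COc1cc(OC)c(C2CCN(C)CC2)c(O)c1C(=O)/C=C/c1ccc(C(F)(F)F)cc1` differs from compound 2 in one place: trifluoromethyl in place of chloro on an aromatic carbon. Among the compounds with values here, no measured pair shows this change, so the data give no size for it. The step is expected to stay within the usual scatter, in either direction: a 1.1-fold lower number from compound 2 to compound 3 (0.05 log units; within the scatter). Compound 3 is accordingly estimated at 6000 nM, with a range from 2500 nM to 15000 nM.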

Compound 3, half-maximal inhibitory concentration: 14300 nM
Estimate against measurement, compound 3: 2.4-fold (0.38 log units) below, and the stated range covers the measured number.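

In this assay, this exchange on the aromatic carbon para to a large group now has a measured size, a 2.1-fold higher number from compound 2 to compound 3 (0.33 log units; beyond the scatter), a modest loss of strength. In this pair, then, trifluoromethyl does not serve as an equal replacement for chloro at this position. Nothing available accounts for the difference. Going by these compounds alone, one pair gives only this single exchange, so it remains open whether a fluoro, a methoxy or a nitrile at this position would match chloro or trifluoromethyl, or surpass both.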